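Chloro for fluoro on the aryl group of compound 1

This account rests on a few compounds, and the source may have more. Where it says the series, first, only, none or still open, it means among the compounds named here.

Measured compounds in an ADME assay on TZM cells (Homo sapiens) for cytotoxicity, read by MTT assay, with a stated time of 48 h; on this read-out lower numbers stand for higher toxicity in this test and higher numbers for lower toxicity in this test:
compound 1 `Cc1ccc(NS(=O)(=O)N2C(=O)CSC2c2c(F)cccc2Cl)cc1`, value 136000 nM
compound 2 `O=C1CSC(c2c(Cl)cccc2Cl)N1C(=O)Nc1ccncc1`, value 170000 nM
compound 3 `Cc1cc(C)nc(N2C(=O)CSC2c2ccc(C#N)cc2)n1`, value 113000 nM

Compound 1 gives the middle number of the three in this assay; its value lies close to that of compound 3 and to that of compound 2, and both gaps are within the usual scatter, so the three compounds cannot be told apart on this read-out.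

Compound 4 `Cc1ccc(NS(=O)(=O)N2C(=O)CSC2c2c(Cl)cccc2Cl)cc1` is not yet measured. It differs from compound 1 by chloro in place of fluoro on an aromatic carbon. No pair of measured compounds shows a comparable single change, so there is no shown step to lean on. Given that all three measured compounds sit close together in this assay, the expected step for compound 4 is small, a 1.1-fold lower number from compound 1 to compound 4 (0.05 log units; within the scatter), not clearly beyond the scatter in either direction. Compound 4 is thus estimated at 120000 nM, with a range from 60000 nM to 240000 nM.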

Compound 4, half-maximal cytotoxic concentration: 75700 nM
Beside the measured number, compound 4's estimate is 1.6-fold (0.20 log units) above it, within the range that was stated.
By their numbers in this assay, from the lowest: compounds 4, 3, 1 and 2 (each within the scatter of the next, the first and the last beyond it).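

Among the compounds shown here, this pair gives the series its only single-place comparison: in this assay 2-chloro-6-fluorophenyl to 2,6-dichlorophenyl is a 1.8-fold lower number from compound 1 to compound 4 (0.25 log units; within the scatter), so chloro in place of fluoro at this position leaves a step that cannot be separated from the scatter. No measurement on hand bears on why the number falls where it does. From the compounds shown here alone, an amine or a methoxy group at this position remains open. Also open, going by these compounds, is whether the same change reads alike when the sulfonyl-linked tolyl amine group of compound 1 gives way to other groups on the shared core.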